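This account rests on a few compounds, and the source may have more. Where it says the series, first, only, none or still open, it means among the compounds named here.

Working notes on a small set of chalcone-type pyrazoles tested in a functional assay on NCI/ADR-RES cells (Homo sapiens) for inhibition, read by sulforhodamine B assay, with a stated time of 48 h; a lower number here means a stronger inhibitor of growth, a higher number a weaker inhibitor of growth. Compound 1 `COc1cc(-c2cc(/C=C/C(=O)c3ccc(N)cc3)[nH]n2)cc(OC)c1OC` gives 3800 nM. Compound 2 `COc1ccc(C(=O)/C=C/c2cc(-c3cc(OC)c(OC)c(OC)c3)n[nH]2)cc1OC` gives 3130 nM, and compound 3 `COc1ccc(C(=O)/C=C/c2cc(-c3cc(OC)c(OC)c(OC)c3)n[nH]2)cc1` gives 2700 nM. All three sit close together: a 1.2-fold lower number from compound 1 to compound 2 (0.08 log units; within the scatter), a 1.4-fold lower number from compound 1 to compound 3 (0.15 log units; within the scatter) and a 1.2-fold lower number from compound 2 to compound 3 (0.06 log units; within the scatter), so no ordering among them can be read off.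

Compound 4 `COc1ccc(-c2cc(/C=C/C(=O)c3ccc(N)cc3)[nH]n2)cc1OC` awaits measurement. It differs from compound 1 by hydrogen in place of methoxy on an aromatic carbon. The measured pair compound 2 to compound 3 carries the corresponding change, (hydrogen in place of methoxy on an aromatic carbon), which produced a 1.2-fold lower number from compound 2 to compound 3 (0.06 log units; within the scatter). The two places are not identical: in compound 1 the aromatic carbon in question is also meta to a methoxy group, which compound 2 lacks, so this is the same kind of change rather than the same change. The cores of compound 1 and compound 2 themselves differ by 4-aminophenyl in place of 3,4-dimethoxyphenyl on a carbonyl carbon.

With one precedent only, the step expected is a 1.2-fold lower number from compound 1 to compound 4 (0.06 log units; within the scatter), resting on a 1.2-fold lower number from compound 2 to compound 3 (0.06 log units; within the scatter). Compound 4 is estimated at 3300 nM, expected to lie between 1700 nM and 6500 nM.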

Compound 4, concentration for 50% growth inhibition: 6210 nM
Beside the measured number, compound 4's estimate is 1.9-fold (0.27 log units) below it, within the range that was stated.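

Hydrogen in place of methoxy on an aromatic carbon of the core of compound 1 gives a 1.6-fold higher number from compound 1 to compound 4 (0.21 log units; within the scatter) in this assay. Set beside the same change on the other core, the two steps carry opposite signs, but the gap between them is no larger than repeated measurements allow: the same change on two cores in this assay, a 1.2-fold lower number (0.06 log units; within the scatter) from compound 2 to compound 3 and a 1.6-fold higher number (0.21 log units; within the scatter) from compound 1 to compound 4, 1.9-fold (0.28 log units) apart, within the scatter of two such steps. The change therefore carries across these two cores without a detectable difference, but two small steps on two cores do not show that it has no effect in this series, nor that it would behave the same way on a further core.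

Every group varied in the compounds shown is a methoxy, a hydrogen or an amino group, so the outcome with a hydroxyl, a fluorine or a longer alkoxy chain such as ethoxy in place of that methoxy remains open. Also open, on these data alone, is whether an amide or a carboxylic acid in place of the amino group of compound 1 would move the number beyond the scatter.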